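The source may hold more compounds than are shown below. What is called first, only, known or untested is meant among the compounds shown, and "the series" means these compounds.

Compound 3 `CC(C)(Oc1ccccc1[N+](=O)[O-])C1OCC(C/C=C\CCC(=O)O)C(c2cccnc2)O1` carries a 2-nitrophenyl group on an oxygen on a saturated carbon of the shared core. In an assay for inhibition of prostacyclin synthase (Homo sapiens), using microsomes (on this read-out lower numbers stand for stronger inhibition and higher numbers for weaker inhibition), compound 3 gives < 1000 nM, which is a limit of the assay rather than a number. Two companions differ from it only in the group on that oxygen. Compound 1 `Cc1ccc(C#N)c(OC(C)(C)C2OCC(C/C=C\CCC(=O)O)C(c3cccnc3)O2)c1` gives > 100000 nM in this assay, again a limit. Compound 2 `CSc1ccccc1OC(C)(C)C1OCC(C/C=C\CCC(=O)O)C(c2cccnc2)O1` gives > 100000 nM in this assay, also a limit. The step of an at least 100-fold lower number from compound 1 to compound 3 (2.00 log units; beyond the scatter) and the step of an at least 100-fold lower number from compound 2 to compound 3 (2.00 log units; beyond the scatter) both run toward the nitro compound, while the step that the two limits leave unreadable from compound 1 to compound 2 cannot be read. Compound 3 is the only one of the three to reach the lower limit (the limit of < 1000 nM in this assay, at which 1 of the 3 values shown sits); the other two sit at the upper limit (the limit of > 100000 nM in this assay, at which 2 of the 3 values shown sit). Compound 4 `CC(C)(Cc1ccc(F)cc1)C1OCC(C/C=C\CCC(=O)O)C(c2cccnc2)O1` differs from compound 3 by 4-fluorobenzyl in place of 2-nitrophenoxy on a saturated chain carbon bound to two saturated chain carbons and a saturated ring carbon. Compound 1 and compound 2, which both lack the nitro group, gave only limits at the weak end. Compound 4 also lacks the nitro group, and the oxygen as well, so a large rise in the number is expected, of the size an at least 30-fold higher number from compound 3 to compound 4 (1.47 log units; beyond the scatter). Compound 4 is therefore estimated at 30000 nM, with a range from 3000 nM to 150000 nM.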

Compound 4, half-maximal inhibitory concentration: 2000 nM
The estimate for compound 4 lay 15-fold (1.18 log units) above the measured number, outside the stated range (below it).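

Going by these compounds alone, until this result, only the 2-nitrophenyl group had given a low number at this position in this assay, but 4-fluorobenzyl, which has neither the nitro group nor the oxygen, also lies far on the strong side of the two weak compounds, with an at least 50-fold lower number from compound 2 to compound 4 (1.69 log units; beyond the scatter) and with an at least 50-fold lower number from compound 1 to compound 4 (1.69 log units; beyond the scatter). A nitro group and an oxygen on this saturated chain carbon are therefore not required for a low number, although compound 1 and compound 2 show that the group placed here still matters greatly. Against the nitro compound the data give only an at least 2.0-fold higher number from compound 3 to compound 4 (0.30 log units; that floor lies within the scatter), and the true size of this step stays unknown because the number for compound 3 is a limit: the limit of < 1000 nM in this assay, at which 1 of the 4 values shown sits.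

Compound 4 removes the oxygen and the nitro group and adds a fluorine in one change, so the compounds shown do not separate what each of these contributes. Open too, from the compounds shown here alone, is how 2-nitrobenzyl, which keeps the nitro group without the oxygen, or plain benzyl, which lacks the fluorine, would read in this assay.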